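Extending the chain and adding chlorine beyond compound 3

A few compounds are considered here, and "the series" means these few. Any claim that something is new, unique, unknown or untested is made for them only; others in the source may bear on it.

Of the compounds shown here, three sharing one core have been measured in an in vitro assay on cells for inhibition of Amine oxidase [flavin-containing] B (Homo sapiens), read by fluorescence and Amplex Red, with stated times of 30 min and 45 min; on this read-out lower numbers stand for stronger inhibition and higher numbers for weaker inhibition. Compound 1 `CN(C(=O)CCCc1ccccc1)c1nc2ccccc2c(=O)s1` gives 53.1 nM, compound 2 `O=C(C/C=C/c1ccccc1)Nc1nc2ccccc2c(=O)s1` gives 39.8 nM, and compound 3 `O=C(CCc1ccccc1)Nc1nc2ccccc2c(=O)s1` gives 17.6 nM. Compound 3 thus stands lowest of the three: compound 2 sits the nearest, with a number beyond the scatter, and compound 1 the furthest, also beyond the scatter.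

Compound 4 `O=C(CCCc1cccc(Cl)c1)Nc1nc2ccccc2c(=O)s1` has not yet been measured. It differs from compound 3 in one place: 3-chlorobenzyl in place of phenyl on a saturated chain carbon, two bonds along the chain from a carbonyl carbon. Going by the values given here, no pair of measured compounds shows this same change, so only the spread among compounds 1, 2 and 3 offers guidance, and that spread is modest.

Because compound 3 already gives 17.6 nM, and because the longer-chained compound 1 gives 53.1 nM, he expects the step of a 1.6-fold higher number from compound 3 to compound 4 (0.20 log units; within the scatter) to be small and, if anything, toward a weaker result. He therefore estimates compound 4 at 28 nM, within a range from 10 nM to 80 nM.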

Compound 4, half-maximal inhibitory concentration: > 1000 nM
Compound 4 gave a limit, no number; the forecaster's own chance of this, stated with the estimate: 3%; middle value at least 35-fold (1.55 log units) from the limit.
By their numbers in this assay, from the lowest: compound 3; then compounds 2 and 1 (each within the scatter of the next). At a limit, above all of these: compound 4.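

In this assay compound 4 gives > 1000 nM, which is a limit of the assay and not a number. Going by these compounds alone, this place on the chain proves far more sensitive than the narrow spread among the earlier compounds suggested: 3-chlorobenzyl in place of phenyl gives an at least 56-fold higher number from compound 3 to compound 4 (1.75 log units; beyond the scatter). The size of the loss of inhibition stays bounded on one side only, and the step is the only one shown at this place.

The change joins a longer chain and a chlorine in one step, so what the compounds shown leave open is which of the two carries the loss. An unsubstituted benzyl or a 3-chlorophenyl group at this place, each on the amide with its hydrogen kept, would separate them.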